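The source may report more compounds than this note shows. Statements on the series, on what has been measured and on what is new or still open speak of the compounds shown alone.

Compound 1 `ClCc1ccc(Cn2cnc3c(Cl)ncnc32)cc1` is the stronger of two measured compounds: in a functional assay on NCI-H23 cells (Homo sapiens) for cytotoxicity, read by sulforhodamine B assay, with a stated time of 48 h (on this read-out higher numbers stand for weaker inhibition of growth and lower numbers for stronger inhibition of growth), compound 1 gives 660 nM, while compound 2 `ClCc1cccc(Cn2cnc3nc(Cl)nc(Cl)c32)c1` gives 1540 nM, a higher number that lies beyond the scatter. Compound 3 `ClCc1ccc(Cn2cnc3c(Cl)nc(Cl)nc32)cc1` differs from compound 1 in one place: chloro in place of hydrogen on an aromatic carbon. Compound 2 also carries two chloro groups on its core, but it differs from compound 1 in more than that one place, so it offers no clean guide. A modest step is expected, a 1.4-fold higher number from compound 1 to compound 3 (0.13 log units; within the scatter), likely toward slightly weaker inhibition of growth. Compound 3 is estimated at 900 nM, within 400 nM to 2000 nM.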

Compound 3, concentration for 50% growth inhibition: 7590 nM
Estimate against measurement, compound 3: 8.4-fold (0.93 log units) below, and the stated range ends below it.
By their numbers in this assay, from the lowest: compound 1; then compound 2; then compound 3.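

On the core of compound 1, the aromatic carbon between two ring nitrogen atoms proves highly sensitive to substitution: in this assay, chloro in place of hydrogen there gives a 12-fold higher number from compound 1 to compound 3 (1.06 log units; beyond the scatter) and so moves the compound toward much weaker inhibition of growth. A single added chlorine atom is enough for a large loss at this position. No measurement here accounts for the size of this step.

Going by these compounds, whether an amine or a methoxy group on this same carbon would behave more like hydrogen or more like chloro remains open.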